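The compounds below may be only part of what the source reports. "The series", "measured", "known", "first", "only" and "open" are said of these compounds alone.

Three compounds share one core and differ at the end carrying the carboxylic acid and at the chain next to the ketone. Compound 1 `COc1cc(C(=O)O)ccc1OCCCCOc1ccc(C(=O)CC(C)(C)C)c(O)c1C` gives 98.6% in an assay on HEK293 cells for positive allosteric modulation of metabotropic glutamate receptor 2 (Rattus norvegicus), read by thallium flux, with a stated time of 2.5 min; on this read-out higher numbers stand for larger maximal responses and lower numbers for smaller maximal responses. Compound 2 `Cc1c(OCCCCOc2ccccc2C(=O)O)ccc(C(=O)CC(C)C)c1O` gives 92.4%, which lies within the scatter of compound 1, so no order can be read between those two. Compound 3 `Cc1c(OCCCCOc2ccc(C(=O)O)c(Cl)c2)ccc(C(=O)CC(C)C)c1O` gives 80.5%, a smaller number than compound 1 by more than the scatter. Among the compounds with values here, the one measured step, a number 11.9 percentage points lower from compound 2 to compound 3 (beyond the scatter), concerns the acid-bearing ring, not the chain at the ketone.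

Compound 4 `CCC(=O)c1ccc(OCCCCOc2ccc(C(=O)O)cc2OC)c(C)c1O` differs from compound 1 in that chain: methyl in place of tert-butyl on a saturated chain carbon bound to a carbonyl carbon. Within the data shown here, no measured pair reports a change of this kind, so nothing measured bears on it directly; the only guide is that the shared core keeps a large maximal response across all three compounds. The expectation is therefore a step of roughly a number 8.6 percentage points lower from compound 1 to compound 4 (within the scatter), that is, no movement beyond the scatter. Compound 4 is estimated at 90%, between 70% and 105%.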

Compound 4, largest response reached (reported as percent of maximum), in percent of the reference or control that the assay uses: 86.5%
Compound 4: the middle estimate sits 3.5 percentage points above what was measured, within the range that was stated.
By their numbers in this assay, from the lowest: compounds 3, 4, 2 and 1 (each within the scatter of the next, the first and the last beyond it).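

In this assay, within the data shown here, the chain at the ketone proves able to shift the response: methyl in place of tert-butyl on a saturated chain carbon bound to a carbonyl carbon gives a number 12.1 percentage points lower from compound 1 to compound 4 (beyond the scatter), the first measured step at this position. The step is modest, and compound 4 still reaches 86.5%, so a large maximal response in this series does not depend on the tert-butyl group. No available measurement explains this drop.

An ethyl or a phenyl group in the same place on the core of compound 1 could show whether the response follows the size of this group or depends on something particular to tert-butyl. On these data alone, it also remains open whether the same change gives a similar step when the acid-bearing ring is that of compound 2 or compound 3.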